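The compounds below may be only part of what the source reports. "The series", "measured", "known", "first", "only" and "open" are said of these compounds alone.

Three compounds of this set have so far been examined in an ADME assay on HEL cells (Homo sapiens) for cytotoxicity, read by microscopy; a higher number here means that more compound is tolerated, a lower number that less compound is tolerated. Compound 1, `Cc1nc(NCCCCNc2ccnc3cc(Cl)ccc23)nc(-c2ccccc2[N+](=O)[O-])c1C(=O)OC(C)C`, gives 20000 nM there. Compound 2, `CCOC(=O)c1c(C)nc(NCCCCNc2ccnc3cc(Cl)ccc23)nc1-c1ccccc1`, reaches only the limit of this assay, > 20000 nM. Compound 3, `CCOC(=O)c1c(C)nc(NCCCNc2ccnc3cc(Cl)ccc23)nc1-c1ccccc1`, likewise reaches only the limit of this assay, > 20000 nM. Compound 2 therefore stands not at a number but at a limit, and of the other two values shown one more is a limit, while the value of compound 1 is a number that coincides with that same figure.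

The fourth compound, compound 4, `CCOC(=O)c1c(C)nc(NCCCCNc2ccnc3cc(Cl)ccc23)nc1C`, has not yet been measured in this assay. It differs from compound 2 in one place: methyl in place of phenyl on an aromatic carbon. Among the measured compounds shown here, no pair of measured compounds differs in a single place, so no measured step guides this change. Given (the limit of > 20000 nM in this assay, at which 2 of the 3 values shown sit), and compound 1 resting at the same figure as a number, no step beyond the usual scatter is expected in this assay in either direction. Compound 4 is accordingly expected to give 20000 nM, within 10000 nM to 40000 nM. The expected step is a number no higher from compound 2 to compound 4 (the limit leaves the size open), with a strong chance that this assay once more reports only a limit and no number.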

Compound 4, minimum cytotoxic concentration: > 20000 nM
Compound 4 ended at the assay's limit; the forecaster's own chance of this, stated with the estimate: 70%; the middle value sits exactly at the limit.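

In this assay compound 4 gives > 20000 nM, which is a limit and not a number, and compound 2 also stands at a limit, so no step can be read between compound 2 and compound 4. The compounds shown leave open what methyl in place of phenyl does to the tolerated concentration in this assay.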